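A Methoxy Swap on a Benzyl Thioether Tail

The source may hold more compounds than are shown below. What is called first, only, known or untested is meant among the compounds shown, and "the series" means these compounds.

Three measured compounds share one core and differ only in the substituent on the benzyl group of the thioether arm. Compound 1 `Cc1cc(N2CC[C@@H](C)[C@@H](N(C)c3ncnc4[nH]ccc34)C2)n2nc(SCc3ccccc3)nc2n1` carries a plain benzyl group, and in a toxicity assay on GES1 cells (Homo sapiens) for inhibition, read by MTT assay, with a stated time of 72 h (on this read-out higher numbers stand for weaker inhibition and lower numbers for stronger inhibition), compound 1 gives 67200 nM. Compound 2 `Cc1cc(N2CC[C@@H](C)[C@@H](N(C)c3ncnc4[nH]ccc34)C2)n2nc(SCc3ccc(Cl)cc3)nc2n1` carries a chloro group on that ring. In this assay compound 2 gives > 100000 nM, which is a limit of the measurement rather than a number. Compound 3 `Cc1cc(N2CC[C@@H](C)[C@@H](N(C)c3ncnc4[nH]ccc34)C2)n2nc(SCc3ccccc3Br)nc2n1` carries a bromo group instead. For compound 3 this assay again reports a limit, > 100000 nM. Compound 2 therefore stands at the weak end of what is shown, sitting at the limit of > 100000 nM in this assay, at which 2 of the 3 values shown sit.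

Within the data shown here, compound 4 `COc1ccc(CSc2nc3nc(C)cc(N4CC[C@@H](C)[C@@H](N(C)c5ncnc6[nH]ccc56)C4)n3n2)cc1` is the compound to be measured next. methoxy in place of chloro on an aromatic carbon The steps that bear on this change are an at least 1.4-fold higher number from compound 1 to compound 2 (0.17 log units; that floor lies within the scatter) and an at least 1.4-fold higher number from compound 1 to compound 3 (0.17 log units; that floor lies within the scatter), both of which stayed within the scatter in their readable part and ran into the limit, while the pair of limits gives a step that the two limits leave unreadable from compound 2 to compound 3. On that basis no shift beyond the scatter is expected for compound 4, and the expected step is an at least 1.0-fold lower number from compound 2 to compound 4 (0.02 log units; that floor lies within the scatter). In this assay compound 4 is estimated at 95000 nM, in the range 40000 nM to 250000 nM, with a limit being the most likely report once more.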

Compound 4, half-maximal inhibitory concentration: > 100000 nM
Compound 4 ended at the assay's limit; the forecaster's own chance of this, stated with the estimate: 65%; middle value at least 1.0-fold (0.02 log units) away from the limit.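

With methoxy on the ring in place of chloro, the group gains an oxygen counted as a hydrogen-bond acceptor, yet the read-out does not come back into the measurable range: in this assay compound 4 gives > 100000 nM, which is a limit and not a number. Set against the unsubstituted benzyl group, the only readable result is an at least 1.4-fold higher number from compound 1 to compound 4 (0.17 log units; that floor lies within the scatter), so this floor does not separate compound 4 from compound 1, and the steps linking compound 4 with compound 2 and compound 3 cannot be read, as both ends of each are limits. What the new compound adds is that a chloro, a bromo and now a methoxy variant all end at the same reporting edge, so the result no longer rests on halogens alone: the limit of > 100000 nM in this assay, at which 3 of the 4 values shown sit.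

Going by these compounds, how far compound 2, compound 3 and compound 4 lie past that limit stays unknown, so no order among them can be given. The compounds shown also leave open whether an amine or a carboxylic acid on this ring would give a number that can be read in this assay.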